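Extending a long amide chain by two carbons

The compounds below may be only part of what the source reports. "The series", "measured", "known", "first", "only" and "open" are said of these compounds alone.

Compound 2 `CCCCCCCCCCCCCCCCCCCC(=O)Nc1ccn([C@@H]2CO[C@H](CO)O2)c(=O)n1` gives 30 nM in a functional assay on A549 cells (Homo sapiens) for cytotoxicity, read by sulforhodamine B assay, with a stated time of 72 h (on this read-out higher numbers stand for weaker inhibition and lower numbers for stronger inhibition), the higher of the two numbers measured, while compound 1 `CCCCCCCCCCCC(=O)Nc1ccn([C@@H]2CO[C@H](CO)O2)c(=O)n1` gives 15 nM. The step of a 2.0-fold higher number from compound 1 to compound 2 (0.30 log units; within the scatter) shows that a large lengthening of the chain changed little. Compound 3 `CCCCCCCCCCCCCCCCCCCCCC(=O)Nc1ccn([C@@H]2CO[C@H](CO)O2)c(=O)n1` differs from compound 2 by ethyl in place of hydrogen on a saturated chain carbon, ten or more bonds along the chain from a carbonyl carbon. That change is far smaller than the octyl extension already tested, so no step beyond the scatter is expected in this assay, as a 1.2-fold higher number from compound 2 to compound 3 (0.07 log units; within the scatter) states. Compound 3 is therefore estimated at 35 nM, within a range of 15 nM to 85 nM.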

Compound 3, half-maximal inhibitory concentration: 500 nM
Beside the measured number, compound 3's estimate is 14-fold (1.15 log units) below it, outside the stated range (above it).
By their numbers in this assay, from the lowest: compounds 1 and 2 (each within the scatter of the next); then compound 3.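

Added length on the chain does not act evenly in this assay: the ethyl addition gives a sharp rise (a 17-fold higher number from compound 2 to compound 3 (1.22 log units; beyond the scatter)), whereas the longer octyl addition stayed within the scatter (a 2.0-fold higher number from compound 1 to compound 2 (0.30 log units; within the scatter)). The decyl addition, taken as a whole, gives a similarly large rise (a 33-fold higher number from compound 1 to compound 3 (1.52 log units; beyond the scatter)), so nearly all of it comes with the final ethyl. Nothing available explains this abrupt change. Still open, from the compounds shown here alone, is whether a longer chain would raise the number further, and whether an amine on the chain would change it.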